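Trifluorophenyl Replacing Chlorofluorophenyl: Expected Vero Cell Toxicity

The source may hold more compounds than are shown below. What is called first, only, known or untested is meant among the compounds shown, and "the series" means these compounds.

Compound 3 `C[C@]1(CN2CCc3nc(-c4cccc(Cl)c4F)ccc3C2)Cn2cc([N+](=O)[O-])nc2O1` was examined in an ADME assay on Vero cells (Chlorocebus sabaeus) for cytotoxicity, read by MTT assay, with a stated time of 72 h; on this read-out higher numbers stand for lower toxicity in this test and lower numbers for higher toxicity in this test. For compound 3 the outcome is a limit of the assay rather than a number, > 32 ug/mL. Compound 2 `C[C@]1(CN2CCc3nc(-c4cccc(F)c4F)ccc3C2)Cn2cc([N+](=O)[O-])nc2O1` shares the same core and differs only in the halogen on the phenyl ring. In this assay compound 2 likewise reports only a limit, > 32 ug/mL. Going by the values given here, the single measured step is therefore a step that the two limits leave unreadable from compound 2 to compound 3. For compound 1 `C[C@]1(CN2CCc3nc(-c4ccc(OC(F)(F)F)cc4)ccc3C2)Cn2cc([N+](=O)[O-])nc2O1` the entry in this assay is "not determined" (no result reported). Compound 3 thus stands at the limit of > 32 ug/mL in this assay, at which 2 of the 3 values shown sit, and no measured value of this series lies elsewhere.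

Compound 4 `C[C@]1(CN2CCc3nc(-c4cc(F)c(F)c(F)c4)ccc3C2)Cn2cc([N+](=O)[O-])nc2O1` carries 3,4,5-trifluorophenyl in place of 3-chloro-2-fluorophenyl on an aromatic carbon. Among the compounds with values here, the only measured step, a step that the two limits leave unreadable from compound 2 to compound 3, gives no readable size, so the two compounds whose values exist do not reveal any move beyond the scatter in this assay. No step beyond the scatter is expected for this change. My estimate for compound 4 in this assay is 50 ug/mL, with a range from 20 ug/mL to 130 ug/mL, most likely again reported only as a limit. The expected step is a step that the limit leaves unreadable from compound 3 to compound 4.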

Compound 4, half-maximal cytotoxic concentration: > 32 ug/mL
Compound 4 gave a limit, no number; the forecaster's own chance of this, stated with the estimate: 75%; the middle value is on the limit's open side.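

Compound 4 gives only a limit in this assay, as do compound 2 and compound 3, so no step among these three compounds can be read. Still open is where each compound's true value lies, and whether changing the halogens on the phenyl ring matters in this test at all: the limit of > 32 ug/mL in this assay, at which 3 of the 4 values shown sit.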